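This account rests on a few compounds, and the source may have more. Where it says the series, first, only, none or still open, it means among the compounds named here.

Compound 1 `CCOc1ccc2nc(Nc3nc4ccc(F)cc4s3)sc2c1` gives 33200 nM in a functional assay on B16-F10 cells (Mus musculus) for cytotoxicity, read by MTT assay, with a stated time of 48 h; a lower number here means a stronger inhibitor, a higher number a weaker inhibitor. Compound 2 `Fc1ccc2nc(Nc3nc4ccc(F)cc4s3)sc2c1` gives 47500 nM in this assay. The step of a 1.4-fold higher number from compound 1 to compound 2 (0.16 log units; within the scatter) arises from fluoro in place of ethoxy on an aromatic carbon, so the two values show no separation that the assay can resolve.

Compound 3 `CCOc1ccc2nc(NC(=S)Nc3ccccc3)sc2c1` is reported only as a limit, > 50000 nM, and no number is available for it; this is the limit (the limit of > 50000 nM in this assay, at which 1 of the 3 values shown sits). How the core of compound 3 differs from the core of compound 1 is not broken down here.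

Compound 4 `Fc1ccc2nc(NC(=S)Nc3ccccc3)sc2c1` has not yet been measured in this assay. It differs from compound 3 by fluoro in place of ethoxy on an aromatic carbon, the same change as between compound 1 and compound 2, at the same place on the ring.

Because a 1.4-fold higher number from compound 1 to compound 2 (0.16 log units; within the scatter) was within the scatter, the step that the limit leaves unreadable from compound 3 to compound 4 is expected to be small as well. Compound 4 is therefore expected to give about 70000 nM, with a range from 30000 nM to 200000 nM, and most likely the assay will again report only a limit for compound 4.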

Compound 4, half-maximal inhibitory concentration: > 50000 nM
Compound 4 ended at the assay's limit; the forecaster's own chance of this, stated with the estimate: 70%; the middle value does not contradict the limit.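

Compound 3 and compound 4 are both reported only as limits in this assay, so no step between them can be read: the limit of > 50000 nM in this assay, at which 2 of the 4 values shown sit.

The compounds shown leave open whether fluoro in place of ethoxy on an aromatic carbon makes any difference on the core of compound 3, and what numbers compound 3 and compound 4 would have.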